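Swapping a methyl for chloro on a diaminoquinazoline scaffold

The compounds below may be only part of what the source reports. "The series", "measured", "known", "first", "only" and "open" are said of these compounds alone.

Of the compounds shown here, three have been measured so far in an assay for inhibition of Dihydrofolate reductase (Homo sapiens); a lower number here means a less potent compound, a higher number a more potent compound, by a factor of ten per unit of this negative logarithm. Compound 1 `Nc1nc2ccccc2c(=O)[nH]1` gives 4.31. Compound 2 `Cc1cccc2nc(N)nc(N)c12`, which carries two amino groups and a methyl group, gives 6.09, the highest of the three numbers. Compound 3 `Cc1cccc2nc(N)nc(O)c12` gives 4.8. The only one-place step among these compounds is a number 1.29 log units lower from compound 2 to compound 3 (beyond the scatter), which shows that replacing one of the amino groups with hydroxy costs a great deal of potency.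

Compound 4 `Nc1nc(N)c2c(Cl)cccc2n1` is not yet measured. It differs from compound 2 as follows: chloro in place of methyl on an aromatic carbon. Among the measured compounds shown here, none of the measured steps involves a chloro group or the methyl group, so no measured step bears directly on this change; the one measured step concerns a different position entirely. Because compound 2 gives 6.09 and the two amino groups are kept in compound 4, the change is expected to be small, with a step of a number 0.11 log units higher from compound 2 to compound 4 (within the scatter) in this assay. Compound 4 is therefore expected to give about 6.2, within a range from 5.5 to 6.9.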

Compound 4, logarithm of the reciprocal of the active concentration, log(1/C): 6.25
Estimate against measurement, compound 4: 0.05 log units below; measured number inside the range.
By their numbers in this assay, from the lowest: compound 1; then compound 3; then compounds 2 and 4 (each within the scatter of the next).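

In this assay the change reads as a number 0.16 log units higher from compound 2 to compound 4 (within the scatter), which gives the first information about this aromatic carbon, as the earlier step of a number 1.29 log units lower from compound 2 to compound 3 (beyond the scatter) concerned an amino group elsewhere on the core. Methyl and chloro therefore cannot be told apart here, and a chloro group can take the place of the methyl group on this carbon with no loss of potency beyond the scatter. Nothing available accounts for why the two groups read alike.

From the compounds shown here alone, whether this tolerance extends to other groups on this carbon remains open, for example a longer chain such as ethyl, a methoxy group or an amine. Also open, going by these compounds, is whether chloro and methyl would still read alike with hydroxy in place of amino, as in compound 3.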